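Changing the Amide Aryl Group on a Chromenone Kinase Inhibitor

The compounds below may be only part of what the source reports. "The series", "measured", "known", "first", "only" and "open" are said of these compounds alone.

Measured compounds:
compound 1 `CN(C)c1ccc(C(=O)Nc2cccc(NC(=O)COc3ccc4c(c3)OCCC4=O)c2)cc1` – 144 nM
compound 2 `O=C(COc1ccc2c(=O)ccoc2c1)Nc1cccc(NC(=O)c2ccc(OC(F)(F)F)cc2)c1` – 869 nM

In an assay on isolated protein for inhibition of Rho-associated protein kinase 1 (Homo sapiens), read by scintillation counting, radiometric assay and 33P incorporation, with a stated time of 40 min, in the presence of a further agent that is not named here (a higher number here means a weaker inhibitor, a lower number a stronger inhibitor), compound 1 gives 144 nM, while compound 2 gives 869 nM. Compound 2 thus has the highest number of the two, and its gap to compound 1 lies beyond the usual scatter. Compound 3 `Nc1cccc(C(=O)Nc2cccc(NC(=O)COc3ccc4c(=O)ccoc4c3)c2)c1` arises from compound 2 through the change (3-aminophenyl in place of 4-(trifluoromethoxy)phenyl on a carbonyl carbon). Among the measured compounds shown here, compounds 1 and 2 differ in more than one place; no single measured step guides this change. For compound 3 a modest drop in the number is expected, a 1.9-fold lower number from compound 2 to compound 3 (0.29 log units; within the scatter). For compound 3 the expected value in this assay is 450 nM, with a range from 130 nM to 1500 nM.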

Compound 3, half-maximal inhibitory concentration: 670 nM
Compound 3: the middle estimate sits 1.5-fold (0.17 log units) below what was measured, and the stated range covers the measured number.
By their numbers in this assay, from the lowest: compound 1; then compounds 3 and 2 (each within the scatter of the next).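

In this assay, 3-aminophenyl in place of 4-(trifluoromethoxy)phenyl on the carbonyl carbon gives a 1.3-fold lower number from compound 2 to compound 3 (0.11 log units; within the scatter). This position therefore accepts a swap of the trifluoromethoxy group for an amine, with its added hydrogen-bond donor, without a change beyond the scatter. No supporting data bear on why the two groups read alike. Still open, as far as these compounds go, is whether the amine contributes anything at all. A plain phenyl or a 4-aminophenyl group on the same carbonyl carbon would test this.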